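Moving the Hydroxyl on One Aryl Arm

The compounds below may be only part of what the source reports. "The series", "measured", "known", "first", "only" and "open" are said of these compounds alone.

Compound 1 `Oc1ccccc1-c1cc(-c2cccc(F)c2)cc(-c2ccccc2O)n1`: in a functional assay on HeLa cells (Homo sapiens) for inhibition (on this read-out lower numbers stand for stronger inhibition and higher numbers for weaker inhibition), compound 1 gives only a limit, > 50000 nM.
Compound 2 `Oc1cccc(-c2cc(-c3cccc(F)c3)cc(-c3ccccc3O)n2)c1`: in this assay compound 2 gives only a limit, > 50000 nM.
Compound 3 `Oc1ccccc1-c1cc(-c2ccccc2OC(F)(F)F)cc(-c2ccccc2O)n1`: in this assay compound 3 gives 9750 nM.

Compound 1 and compound 2 differ in one change, (3-hydroxyphenyl in place of 2-hydroxyphenyl on an aromatic carbon). The step that the two limits leave unreadable from compound 1 to compound 2 cannot be sized, since both values sit at the limit of > 50000 nM in this assay, at which 2 of the 3 values shown sit. Compound 4 `Oc1cccc(-c2cc(-c3ccccc3OC(F)(F)F)cc(-c3ccccc3O)n2)c1` is not yet measured and differs from compound 3 by 3-hydroxyphenyl in place of 2-hydroxyphenyl on an aromatic carbon. This is the same kind of change, though the surroundings differ: in compound 1 the place is meta to a 3-fluorophenyl group, in compound 3 meta to a large group. The difference between the cores of compound 1 and compound 3 is not broken down here. The expectation for compound 4 rests on compound 3 with 9750 nM and on the unreadable a step that the two limits leave unreadable from compound 1 to compound 2. Compound 4 is expected to show a step of a 2.1-fold higher number from compound 3 to compound 4 (0.31 log units; beyond the scatter), and its estimated value is 20000 nM, likely between 6000 nM and 60000 nM.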

Compound 4, half-maximal inhibitory concentration: 15200 nM
Beside the measured number, compound 4's estimate is 1.3-fold (0.12 log units) above it, within the range that was stated.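

In this assay, 3-hydroxyphenyl in place of 2-hydroxyphenyl gives a 1.6-fold higher number from compound 3 to compound 4 (0.19 log units; within the scatter), so on the core of compound 3 this change cannot be told apart from repeat measurements. The same change on the core of compound 1 cannot be read, since compound 1 and compound 2 each give only a limit of the assay: the limit of > 50000 nM in this assay, at which 2 of the 4 values shown sit. Whether the change carries from one core to the other is therefore not shown, as the single readable step has no second step to set against it.

The compounds shown leave open how an amine or a carboxylic acid in place of the hydroxyl on this arm would read in this assay. They also leave open how this change would read on a third core.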